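This account rests on a few compounds, and the source may have more. Where it says the series, first, only, none or still open, it means among the compounds named here.

Compound 1 `O=S(=O)(Nc1ccc(Cl)cc1)c1ccc(-c2cnc(C3CC3)o2)cc1`: 57400 nM
Compound 2 `O=S(=O)(Nc1ccc(Cl)c(C(F)(F)F)c1)c1ccc(-c2cnc(C3CC3)o2)cc1`: 55400 nM

For the measured compounds named here, in a functional assay on cells (Panel NCI-60 (60 carcinoma cell lines), Homo sapiens) for inhibition, read by sulforhodamine B assay, with a stated time of 48 h (a lower number here means that less compound is tolerated, a higher number that more compound is tolerated), compound 1 gives 57400 nM, level with its only measured neighbour. Going by the values given here, that neighbour carries trifluoromethyl in place of hydrogen on an aromatic carbon, and the one measured step, a 1.0-fold lower number from compound 1 to compound 2 (0.02 log units; within the scatter), is all that bears on the next change.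

Compound 3 `O=S(=O)(Nc1ccc(Br)cc1)c1ccc(-c2cnc(C3CC3)o2)cc1` has bromo in place of chloro on an aromatic carbon, para to a large group: bromo in place of chloro on an aromatic carbon. That step is a different swap, so it is only a loose guide, and no shift beyond the scatter is expected.

The expected step is a 1.0-fold lower number from compound 1 to compound 3 (0.02 log units; within the scatter). For compound 3 the estimate is 55000 nM, with an expected range of 35000 nM to 85000 nM.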

Compound 3, concentration lethal to 50% of the cells: 54000 nM
Estimate against measurement, compound 3: 1.0-fold (0.01 log units) above, within the range that was stated.
By their numbers in this assay, from the lowest: compounds 3, 2 and 1 (each within the scatter of the next).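

In this assay, bromo in place of chloro gives a 1.1-fold lower number from compound 1 to compound 3 (0.03 log units; within the scatter). Until now the chloro itself had stayed in both compounds; here it gives way to bromo, para to a large group, without a step beyond the scatter. No measurement on hand explains this result. Still open, as far as these compounds go, is whether a group other than a halogen at this position, such as an amine or a carboxylic acid, would move the number. So is whether a change elsewhere on the core of compound 1 would.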